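A few compounds are considered here, and "the series" means these few. Any claim that something is new, unique, unknown or untested is made for them only; others in the source may bear on it.

Measured compounds:
Compound 1 `COc1ccc(C(O)(c2cc3cc([N+](=O)[O-])cc(-c4ccccc4)c3o2)c2cncn2C)cc1`: 4970 nM
Compound 2 `COc1cccc(-c2cc([N+](=O)[O-])cc3cc([C@](N)(c4ccc(C#N)cc4)c4cncn4C)oc23)c1`: 1.1 nM
Compound 3 `Cn1cncc1[C@@](N)(c1ccc(C#N)cc1)c1cc2cc(C#N)cc(-c3cccc(C#N)c3)c2o1`: 2 nM

In a functional assay on QG-56 cells (Homo sapiens) for antiproliferative activity (on this read-out higher numbers stand for weaker inhibition and lower numbers for stronger inhibition), compound 1 gives 4970 nM, the highest of the three numbers, so it is the weakest inhibitor here: compound 3 and compound 2 lie far below it, well beyond the scatter of repeated measurements. Compound 4 `Cn1cncc1C(O)(c1ccc(Br)cc1)c1cc2cc([N+](=O)[O-])cc(-c3ccccc3)c2o1` has not yet been tested in this assay. It is built from compound 1 by one change: bromo in place of methoxy on an aromatic carbon. Going by the values given here, no measured pair shows what this change does on its own, so the expectation rests on compound 1 alone. A swap of one small group for another at this position is expected to move the number little, and the step of a 1.4-fold lower number from compound 1 to compound 4 (0.15 log units; within the scatter) is expected to stay within or near the scatter. Compound 4 is therefore expected to give about 3500 nM, in the range 1200 nM to 12000 nM.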

Compound 4, half-maximal inhibitory concentration: 1480 nM
The estimate for compound 4 lay 2.4-fold (0.37 log units) above the measured number, and the stated range covers the measured number.
By their numbers in this assay, from the lowest: compounds 2 and 3 (each within the scatter of the next); then compound 4; then compound 1.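

In this assay bromo in place of methoxy gives a 3.4-fold lower number from compound 1 to compound 4 (0.53 log units; beyond the scatter) and so shows that this place on the ring, para to a large group, responds to what sits on it. The response is modest, but 4-methoxyphenyl and 4-bromophenyl are not interchangeable here. Nothing at hand says why the number moves. Going by these compounds, whether an amine, a carboxylic acid or a longer chain such as butoxy at this same place would lower the number further, or raise it, stays open.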